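From aminomethyl to 1-aminocyclopropyl on a shared core

The source may hold more compounds than are shown below. What is called first, only, known or untested is meant among the compounds shown, and "the series" means these compounds.

Of the compounds shown here, three built on a shared core have been tested so far in an in vitro ADME assay on microsomes (Rattus norvegicus) for metabolic stability (a lower number here means that the compound disappears faster, a higher number that the compound lasts longer), on the half-life read-out. Compound 1 (`Cc1c2c(n3c1CCCNC[C@H](C)Nc1cc-3ccc1C(N)=O)CC(C)(C)CC2=O`) gives > 0.5 h as a limit of the measurement, not a number. Compound 2 (`Cc1c2c(n3c1CCN(C(=O)[C@H](C)N)CC[C@H](C)Nc1cc-3ccc1C(N)=O)CC(C)(C)CC2=O`) gives > 0.5 h as a limit too, again not a number. Compound 3 (`Cc1c2c(n3c1CCN(C(=O)CN)C[C@@H](C)[C@H](C)Nc1cc-3ccc1C(N)=O)CC(C)(C)CC2=O`) gives > 0.5 h as a limit as well, so it has no exact half-life. The picture so far is the limit of > 0.5 h in this assay, at which 3 of the 3 values shown sit, and compound 3 therefore cannot be ranked against the other two.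

Compound 4 (`Cc1c2c(n3c1CCN(C(=O)C1(N)CC1)C[C@@H](C)[C@H](C)Nc1cc-3ccc1C(N)=O)CC(C)(C)CC2=O`) has 1-aminocyclopropyl in place of aminomethyl on a carbonyl carbon and is otherwise the same as compound 3. Within the data shown here, no measured pair here differs in one place only, so the data give no direct guide to the size of such a change. In this assay no step beyond the usual scatter is expected, in either direction. That expectation rests on compound 3, whose reading of > 0.5 h is a limit. The expected step is a step that the limit leaves unreadable from compound 3 to compound 4 and it is only an estimate. The estimate for compound 4 is 0.6 h with an expected range from 0.3 h to 1.2 h and the reading may well come back as a limit again.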

Compound 4, half-life: > 0.5 h
Compound 4: only a limit was reported (the forecaster's own chance of this, stated with the estimate: 75%); the middle value does not contradict the limit.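

In this assay compound 4 gives > 0.5 h, which is a limit and not a number. Compound 3 also reads as a limit, so no step from compound 3 to compound 4 can be read, because the values all stop at the same point: the limit of > 0.5 h in this assay, at which 4 of the 4 values shown sit.

The exact half-lives of these compounds remain open, as does whether 1-aminocyclopropyl in place of aminomethyl on a carbonyl carbon changes the half-life at all.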